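Swapping One Five-Membered Ring for Another

The source may hold more compounds than are shown below. What is called first, only, known or untested is meant among the compounds shown, and "the series" means these compounds.

Measured compounds:
compound 1, `COc1cc(N2C(N)=C(C#N)C(c3c(OC)ccc4ccccc34)C3=C2CC(C)(C)CC3=O)cc(OC)c1OC`: 30%
compound 2, `COc1cc(N2C(N)=C(C#N)C(c3cccs3)C3=C2CC(C)(C)CC3=O)cc(OC)c1OC`: 20%

In a functional assay on Ehrlich cells (Mus musculus) for cytotoxicity, tested at 100 ug/mL (on this read-out higher numbers stand for a stronger effect at the one concentration tested and lower numbers for a weaker effect), compound 1 gives 30% and compound 2 gives 20%. Among the measured compounds shown here, compound 2 stands at the foot of these two numbers, but the gap to its only neighbour, compound 1, is a number 10 percentage points lower from compound 1 to compound 2 (within the scatter), so the two results are not told apart.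

Compound 3, `COc1cc(N2C(N)=C(C#N)C(c3ccc(C)o3)C3=C2CC(C)(C)CC3=O)cc(OC)c1OC`, has not yet been measured. It differs from compound 2 in one place: 5-methylfuran-2-yl in place of thiophen-2-yl on a saturated ring carbon.

For the measured compounds named here, one measured step bears on this change. The exchange of one aromatic ring for another on that same saturated ring carbon gave a number 10 percentage points lower from compound 1 to compound 2 (within the scatter). On that basis a step in this assay of no more than the scatter is expected, with no direction to be read from the data.

Compound 3 is therefore expected to give about 20%, in a range from 5% to 35%. The step expected is no change at the digits printed from compound 2 to compound 3 (within the scatter).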

Compound 3, a percentage reported as activity, at one concentration (the size of the read-out at that concentration, not a potency): 50%
Estimate against measurement, compound 3: 30 percentage points below; the measured number lies above the stated range.
By their numbers in this assay, from the lowest: compounds 2 and 1 (each within the scatter of the next); then compound 3.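

In this assay the aromatic group on this saturated ring carbon proves able to move the read-out: 5-methylfuran-2-yl in place of thiophen-2-yl gives a number 30 percentage points higher from compound 2 to compound 3 (beyond the scatter) and the same group in place of 2-methoxynaphthalen-1-yl gives a number 20 percentage points higher from compound 1 to compound 3 (beyond the scatter) on the same carbon. Among the compounds shown here, the one earlier step at this carbon lay within the scatter, so compound 3 is the first compound to stand clear of the others, and it is the most active of the three on this read-out. Nothing at hand gives a reason for this rise.

The change puts oxygen in place of sulfur and adds a methyl at once, so the compounds shown do not tell which of the two goes with the higher number. Plain furan-2-yl and 5-methylthiophen-2-yl would separate the two, and 5-ethylfuran-2-yl or 5-(aminomethyl)furan-2-yl would show how much more this methyl position tolerates.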